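Thioester in place of amide on a dihydropyrimidinone core

A few compounds are considered here, and "the series" means these few. Any claim that something is new, unique, unknown or untested is made for them only; others in the source may bear on it.

Compound 2 `CCN(CC)C(=O)C1=C(C)NC(=O)NC1c1ccoc1` was tested in an assay on membranes from CHO cells for displacement of a labelled ligand from adenosine receptor A1 (Homo sapiens), read by scintillation counting, with a stated time of 60 min, tested at 1 uM (a higher number here means more inhibition at the concentration tested (going by the name of the read-out), a lower number less inhibition), where compound 2 gives 15%. Going by the values given here, its only neighbour so far is compound 1 `CC1=C(C(=O)OC(C)(C)C)C(c2ccoc2)NC(=O)N1`, which in this assay gives 11%; the two numbers lie within the scatter of each other, and the one measured step, a number 4 percentage points higher from compound 1 to compound 2 (within the scatter), shows that swapping the group on the carbonyl carbon left the read-out essentially unchanged. Compound 3 `CC1=C(C(=O)SC(C)C)C(c2ccoc2)NC(=O)N1` differs from compound 2 by isopropylsulfanyl in place of diethylamino on a carbonyl carbon. Since the earlier swap at this carbonyl carbon, a number 4 percentage points higher from compound 1 to compound 2 (within the scatter), was within the scatter, compound 3 is expected to move only by a number 3 percentage points lower from compound 2 to compound 3 (within the scatter). Compound 3 is therefore estimated at 12%, within a range of -5% to 30%.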

Compound 3, a percentage reported as inhibition, at one concentration (the size of the read-out at that concentration, not a potency): 9%
Beside the measured number, compound 3's estimate is 3 percentage points above it; the range from low to high includes it.
By their numbers in this assay, from the lowest: compounds 3, 1 and 2 (each within the scatter of the next).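

In this assay the steps of a number 6 percentage points lower from compound 2 to compound 3 (within the scatter) and a number 2 percentage points lower from compound 1 to compound 3 (within the scatter) show that isopropylsulfanyl on this carbonyl carbon reads the same as diethylamino and tert-butoxy. Three groups attached through sulfur, nitrogen and oxygen therefore give numbers within the scatter of one another, so the kind of linking atom makes no readable difference among these compounds. No measured evidence here speaks to why the read-out stays so flat. Still open, on these data alone, is whether a carboxylic acid, a primary amine or a much longer chain at this place would move the number beyond the scatter.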